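Hydroxy for Chloro on a Chalcone and a Chromone Core

The compounds below may be only part of what the source reports. "The series", "measured", "known", "first", "only" and "open" are said of these compounds alone.

Measured so far:
compound 1 `COc1cc(OC)c(OC)cc1/C=C/C(=O)c1ccc(Cl)cc1` — 2.01 ug/mL
compound 2 `COc1cc(OC)c(-c2cc(=O)c3cc(Cl)ccc3o2)cc1OC` — 2.15 ug/mL
compound 3 `COc1cc(OC)c(OC)cc1/C=C/C(=O)c1ccc(O)cc1` — 2.5 ug/mL

In a functional assay, read by Griess assay, with a stated time of 2.5 h (on this read-out higher numbers stand for weaker inhibition and lower numbers for stronger inhibition), compound 1 gives 2.01 ug/mL and compound 3 gives 2.5 ug/mL. The change from compound 1 to compound 3 is hydroxy in place of chloro on an aromatic carbon; the step it made, a 1.2-fold higher number from compound 1 to compound 3 (0.09 log units; within the scatter), is within the scatter. Compound 2 gives 2.15 ug/mL in this assay, and its value and that of compound 1 lie within the scatter of each other. The difference between the cores of compound 1 and compound 2 is not broken down here.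

Compound 4 `COc1cc(OC)c(-c2cc(=O)c3cc(O)ccc3o2)cc1OC` has not yet been measured. It differs from compound 2 by hydroxy in place of chloro on an aromatic carbon. This is the same kind of change as that from compound 1 to compound 3, but the place differs: in compound 4 the hydroxy sits on a ring that is part of a fused or bridged system of two rings, meta to a fused ring and para to a fused ring, whereas in compound 3 it sits para to a large group.

Because a 1.2-fold higher number from compound 1 to compound 3 (0.09 log units; within the scatter) stayed within the scatter, the step from compound 2 to compound 4 is expected to be small, about a 1.2-fold higher number from compound 2 to compound 4 (0.07 log units; within the scatter). Compound 4 is estimated at 2.5 ug/mL in this assay, between 1.2 ug/mL and 5.5 ug/mL.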

Compound 4, half-maximal inhibitory concentration: 2.14 ug/mL
Compound 4: the middle estimate sits 1.2-fold (0.07 log units) above what was measured, and the stated range covers the measured number.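

In this assay, hydroxy in place of chloro on an aromatic carbon of the core of compound 2 gave a 1.0-fold lower number from compound 2 to compound 4 (0.00 log units; within the scatter). Set beside the earlier step on the core of compound 1, the result is the same on both cores: the same change on two cores in this assay, a 1.2-fold higher number (0.09 log units; within the scatter) from compound 1 to compound 3 and a 1.0-fold lower number (0.00 log units; within the scatter) from compound 2 to compound 4, 1.2-fold (0.10 log units) apart, within the scatter of two such steps. This shows that, across these two pairs, the change carried from one core to the other without moving the number beyond the scatter, even though the hydroxy sits at a different place on each core, but it does not show that the change would stay this small on any further core or at any other place, and steps this small cannot reveal any slight difference between the two cores.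

The compounds shown carry only chloro or hydroxy at these places, so what an amine, a carboxylic acid or a longer chain would do there remains open. From the compounds shown here alone, the methoxy groups are present in all four compounds, so what they contribute to the numbers also remains open.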